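Cytotoxicity Across Four Analogues Sharing One Core

This account rests on a few compounds, and the source may have more. Where it says the series, first, only, none or still open, it means among the compounds named here.

Three compounds share one core and differ only in the group on an aromatic carbon. Compound 1 `CNc1nc(N)nc2c1ncn2/C=C1/CC1(CO)CO` carries a methylamino group there; in an ADME assay on HFF cells (Homo sapiens) for cytotoxicity, with a stated time of 8 days (a lower number here means that less compound is tolerated, a higher number that more compound is tolerated), compound 1 gives 265000 nM. Compound 2 `Nc1nc(OCC(F)(F)F)c2ncn(/C=C3/CC3(CO)CO)c2n1` carries a 2,2,2-trifluoroethoxy group. For compound 2 this assay reports only a limit, > 300000 nM. Compound 3 `CC(C)CSc1nc(N)nc2c1ncn2/C=C1/CC1(CO)CO` carries an isobutylsulfanyl group. For compound 3 this assay likewise reports only a limit, > 300000 nM. Compound 3 therefore stands at the limit, and the numbers shown give no exact value for it. The step of an at least 1.1-fold higher number from compound 1 to compound 3 (0.05 log units; that floor lies within the scatter) and the step of an at least 1.1-fold higher number from compound 1 to compound 2 (0.05 log units; that floor lies within the scatter) are both floors lying within the scatter, and the step that the two limits leave unreadable from compound 2 to compound 3 cannot be read because of the limit of > 300000 nM in this assay, at which 2 of the 3 values shown sit.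

Compound 4 `CCOc1nc(N)nc2c1ncn2/C=C1/CC1(CO)CO` is not yet measured. ethoxy in place of isobutylsulfanyl on an aromatic carbon The nearest comparison is compound 2, whose group on that carbon is 2,2,2-trifluoroethoxy and whose result was already a limit. Within the data shown here, since every compound so far sits at or close to the limit, the step of a number no higher from compound 3 to compound 4 (the limit leaves the size open) is expected to be none beyond the scatter. Compound 4 is therefore estimated to give 300000 nM in this assay, with a range from 150000 nM to 600000 nM, most likely again reported only as a limit.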

Compound 4, half-maximal cytotoxic concentration: > 300000 nM
Compound 4 ended at the assay's limit; the forecaster's own chance of this, stated with the estimate: 60%; the middle value lies on the limit itself.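

Compound 4 shows that the limit at this position is reached not only with the 2,2,2-trifluoroethoxy and isobutylsulfanyl groups but also with ethoxy, a group of 3 heavy atoms that carries no fluorine and no sulfur. Set against the methylamino group of compound 1, the change gives an at least 1.1-fold higher number from compound 1 to compound 4 (0.05 log units; that floor lies within the scatter), so this assay shows no difference beyond the scatter for this pair. The steps among compound 2, compound 3 and compound 4 cannot be read, because all three values are limits and only their position relative to that limit is known: the limit of > 300000 nM in this assay, at which 3 of the 4 values shown sit.

The compounds shown therefore leave open how far compound 2, compound 3 and compound 4 actually lie from one another, and whether any of them differs from compound 1 by more than the scatter. They also leave open whether a different group on this aromatic carbon, such as a carboxylic acid, a primary amine or a longer chain like octyloxy, would give an exact half-maximal cytotoxic concentration well under the limit.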